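This account rests on a few compounds, and the source may have more. Where it says the series, first, only, none or still open, it means among the compounds named here.

In a functional assay on ASPC1 cells (Homo sapiens) for cytotoxicity, read by MTT assay (on this read-out higher numbers stand for weaker inhibition and lower numbers for stronger inhibition), compound 2 `O=C(NC(=S)Nc1ccc(Oc2ncccn2)cc1)c1ccccc1` reads "not determined" (no result reported) and so has no single number to start from. In this assay compound 1 `O=C(NC(=O)c1ccccc1)Nc1ccc(Oc2ncccn2)cc1` likewise reads "not determined" (no result reported) and offers no number either. In this assay compound 3 `O=C(NC(=O)c1ccccc1)Nc1ccc(Sc2ncc(Br)cn2)cc1` gives > 10000 nM as a limit of the assay, not a number. Compound 4 `O=C(NC(=S)Nc1ccc(Sc2ncc(Br)cn2)cc1)c1ccccc1` is still unmeasured. The change (5-bromopyrimidin-2-yl)sulfanyl in place of (pyrimidin-2-yl)oxy on an aromatic carbon sets (5-bromopyrimidin-2-yl)sulfanyl in place of (pyrimidin-2-yl)oxy on an aromatic carbon, para to a large group. Without a value for compound 2, no size or direction of step in this assay can be expected from it. Weak inhibition is expected instead, since compound 3, which carries the same entering group, marks the limit of > 10000 nM in this assay, at which 1 of the 3 values shown sits, as the only reference. For compound 4 the estimated value is 10000 nM with an expected range of 3000 nM to 30000 nM in this assay when it is measured.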

Compound 4, half-maximal inhibitory concentration: 10000 nM
Compound 4: middle estimate and measured number agree at the digits printed, and the stated range covers the measured number.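

Going by these compounds alone, compound 2 has no single number in this assay, so no step to compound 4 can be read. As far as these compounds go, what replacing (pyrimidin-2-yl)oxy with (5-bromopyrimidin-2-yl)sulfanyl does to cytotoxicity on this read-out remains open.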